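Reshaping a hydroxy side chain on a shared core

A few compounds are considered here, and "the series" means these few. Any claim that something is new, unique, unknown or untested is made for them only; others in the source may bear on it.

compound 1 `CC(C)=CC[C@@H](OC(=O)C1CCCO1)C1=CC(=O)c2c(O)ccc(O)c2C1=O`: 10500 nM
compound 2 `CCCC(C)(O)CC(=O)O[C@H](CC=C(C)C)C1=CC(=O)c2c(O)ccc(O)c2C1=O`: 75000 nM
compound 3 `CCCCC(C)(O)CC(=O)O[C@H](CC=C(C)C)C1=CC(=O)c2c(O)ccc(O)c2C1=O`: 76500 nM
compound 4 `CCC(O)(CC)CC(=O)O[C@H](CC=C(C)C)C1=CC(=O)c2c(O)ccc(O)c2C1=O`: not yet measured

In a functional assay on DU-145 cells (Homo sapiens) for cytotoxicity, read by MTT assay (on this read-out higher numbers stand for weaker inhibition and lower numbers for stronger inhibition), compound 3 gives 76500 nM, level with compound 2 at 75000 nM. The gap between them is small, with a 1.0-fold higher number from compound 2 to compound 3 (0.01 log units; within the scatter). Compound 1 stands apart from this pair, with a 7.3-fold higher number from compound 1 to compound 3 (0.86 log units; beyond the scatter).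

The next change reshapes the side chain of compound 3: 1-ethyl-1-hydroxypropyl in place of 1-hydroxy-1-methylpentyl on a saturated chain carbon bound to a carbonyl carbon. In words, 1-ethyl-1-hydroxypropyl takes the place of 1-hydroxy-1-methylpentyl. Two measured steps give some guidance. The closest is the small chain change with a 1.0-fold higher number from compound 2 to compound 3 (0.01 log units; within the scatter), which stayed within the scatter. The larger one, a 7.1-fold higher number from compound 1 to compound 2 (0.85 log units; beyond the scatter), replaced oxolan-2-yl, a ring, with an open chain carrying a hydroxy group. Compound 4 keeps an open hydroxy-bearing chain, so that larger step is not repeated here. Among the measured compounds shown here, no measured compound carries the 1-ethyl-1-hydroxypropyl group, however, so the guidance is only indirect.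

No shift beyond the scatter is therefore expected in this assay, and the estimate is a 1.1-fold lower number from compound 3 to compound 4 (0.04 log units; within the scatter). The expected value for compound 4 is 70000 nM, with an estimated range from 35000 nM to 120000 nM.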

Compound 4, half-maximal inhibitory concentration: 67000 nM
Estimate against measurement, compound 4: 1.0-fold (0.02 log units) above; measured number inside the range.
By their numbers in this assay, from the lowest: compound 1; then compounds 4, 2 and 3 (each within the scatter of the next).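

In this assay, among the compounds shown here, the earlier compounds showed only that lengthening the hydroxy-bearing chain changed little, and compound 4 adds that reshaping it changes little too: 1-ethyl-1-hydroxypropyl in place of 1-hydroxy-1-methylpentyl on a saturated chain carbon bound to a carbonyl carbon gives a 1.1-fold lower number from compound 3 to compound 4 (0.06 log units; within the scatter) and the comparison with the 1-hydroxy-1-methylbutyl chain gives a 1.1-fold lower number from compound 2 to compound 4 (0.05 log units; within the scatter) so both the length and the shape of the chain can vary here without a shift beyond the usual scatter. The ring-bearing compound 1 still stands apart from this open-chain group, with a 6.4-fold higher number from compound 1 to compound 4 (0.80 log units; beyond the scatter) and so, among these four compounds, the clear divide lies between the oxolan-2-yl ring and the open hydroxy-bearing chains, with no compound going against it. Nothing available explains either the flat response among the open chains or the gap to the ring.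

Compound 1 differs from the open-chain compounds in having a ring and in lacking the free hydroxy group, so these compounds cannot show which of the two features goes with the gap. An open chain with no hydroxy group, a hydroxy-bearing oxolane ring, or an amine in place of the hydroxy group would help to separate them.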